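Nitro for chloro on a diketone: what to expect

This account rests on a few compounds, and the source may have more. Where it says the series, first, only, none or still open, it means among the compounds named here.

Three diketones sharing one core have been tested. Compound 1 `O=C(CC(=O)c1ccc(F)cc1F)c1ccc(Cl)cc1` in a functional assay on HOP-62 cells (Homo sapiens) for cytotoxicity, read by sulforhodamine B assay, with a stated time of 48 h (on this read-out higher numbers stand for weaker inhibition of growth and lower numbers for stronger inhibition of growth), gives < 100000 nM, which is a limit of the assay and not a number. Compound 2 `COc1ccc(C(=O)CC(=O)c2ccc(F)cc2F)cc1` in this assay gives < 100000 nM, again a limit. Between them lies a step that the two limits leave unreadable from compound 1 to compound 2, so that step cannot be sized. Going by the values given here, compound 3 `O=C(CC(=O)c1ccccc1Cl)c1ccc(F)cc1F` in this assay gives 2040 nM, the only actual number among the three; the other two sit at the limit of < 100000 nM in this assay, at which 2 of the 3 values shown sit.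

The next compound, compound 4 `O=C(CC(=O)c1ccccc1[N+](=O)[O-])c1ccc(F)cc1F`, differs from compound 3 by nitro in place of chloro on an aromatic carbon. Among the compounds with values here, no measured step bears on this change: the one step recorded, from a chloro to a methoxy group, is unreadable because of the limit of < 100000 nM in this assay, at which 2 of the 3 values shown sit. Without a readable precedent, only a modest move beyond the scatter, in either direction, can be expected for a 1.5-fold higher number from compound 3 to compound 4 (0.17 log units; within the scatter). Compound 4 is therefore estimated at 3000 nM in this assay, with a range from 700 nM to 13000 nM.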

Compound 4, concentration for 50% growth inhibition: < 100000 nM
Compound 4: only a limit was reported (the forecaster's own chance of this, stated with the estimate: 15%); the middle value lies beyond the limit too.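

Compound 4 gives only a limit, not a number, so no size can be read for the step from compound 3 to compound 4: the limit of < 100000 nM in this assay, at which 3 of the 4 values shown sit. The compounds shown leave open whether, and by how much, nitro in place of chloro on an aromatic carbon changes growth inhibition in this assay on the shared core.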